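Aminopyrimidine series: isoxazolylmethyl amine replacing butylamine

A few compounds are considered here, and "the series" means these few. Any claim that something is new, unique, unknown or untested is made for them only; others in the source may bear on it.

Compound 2 `CCCCNc1nc(N)nc2ccn(Cc3ccccn3)c12` is the parent of the step considered here, with compound 1 `CCCCNc1nc(N)nc2ccn(Cc3ccccc3)c12` and compound 3 `CCCCNc1nc(N)nc2ccn(Cc3ncccc3OC)c12` alongside. In an ADME assay on HEK293 cells (Homo sapiens) for cytotoxicity, read by ATP content, with a stated time of 6 h (on this read-out lower numbers stand for higher toxicity in this test and higher numbers for lower toxicity in this test), compound 2 gives > 24000 nM, which is a limit of the assay and not a number. Compound 1 in this assay gives > 24000 nM, also a limit. Compound 3 in this assay gives > 24000 nM, again a limit. Compound 2 therefore sits at the limit of > 24000 nM in this assay, at which 3 of the 3 values shown sit, together with the other two, and no order among the three can be read. The steps a step that the two limits leave unreadable from compound 1 to compound 2, a step that the two limits leave unreadable from compound 1 to compound 3 and a step that the two limits leave unreadable from compound 2 to compound 3 are all hidden by the limits, so no change on the saturated chain carbon bound to an aromatic nitrogen, or of the methoxy, is visible in this assay. Compound 4 `Nc1nc(NCc2ccon2)c2c(ccn2Cc2ccccn2)n1` differs from compound 2 by 1,2-oxazol-3-yl in place of propyl on a saturated chain carbon bound to a nitrogen on an aromatic ring. Among the compounds with values here, no measured step touches this side of the shared core. No step beyond the scatter is expected in this assay, and the estimated step is a step that the limit leaves unreadable from compound 2 to compound 4. The estimate for compound 4 is 30000 nM, with a range from 15000 nM to 80000 nM, most likely again reported only as a limit.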

Compound 4, half-maximal cytotoxic concentration: > 24000 nM
Compound 4: a limit, no number; the forecaster's own chance of this, stated with the estimate: 85%; the middle value lies beyond the limit too.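

Compound 4 stays at a limit in this assay, like compound 1, compound 2 and compound 3, so no step involving compound 4 can be read: the limit of > 24000 nM in this assay, at which 4 of the 4 values shown sit.

The compounds shown leave open whether any change on either side of the shared core gives a readable half-maximal cytotoxic concentration.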